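The compounds below may be only part of what the source reports. "The series", "measured", "known", "first", "only" and "open" are said of these compounds alone.

Measured compounds in a functional assay on HeLa cells (Homo sapiens) for cytotoxicity, read by MTT assay, with a stated time of 72 h, tested at 30 uM; on this read-out lower numbers stand for less inhibition of growth and higher numbers for more inhibition of growth at the one concentration tested:

Compound 1, `N/C(=N\NC(=S)N1CCCCCC1)c1ccccn1`, gives 82.9%.
Compound 2, `N/C(=N\NC(=S)N1CCSCC1)c1ccccn1`, gives 80.6%.
Compound 3, `N/C(=N\NC(=S)N1CCSCC1)c1ccc(F)cn1`, gives 81.7%.

All three numbers lie within the usual scatter of one another, so no order among compounds 1, 2 and 3 is claimed from these values. The difference between the core of compound 1 and the core of compound 2 is not broken down here. From compound 2 to compound 3 the change is fluoro in place of hydrogen on an aromatic carbon, and the step it made in this assay is a number 1.1 percentage points higher from compound 2 to compound 3 (within the scatter).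

Compound 4, `N/C(=N\NC(=S)N1CCCCCC1)c1ccc(F)cn1`, is not yet measured. It differs from compound 1 by fluoro in place of hydrogen on an aromatic carbon, and the place of the change is described in the same words as for the pair of compounds 2 and 3, so this is the same change, made on the core of compound 1 instead of the core of compound 2. The expected step in this assay from compound 1 to compound 4 is a number 0.6 percentage points higher from compound 1 to compound 4 (within the scatter), which rests on the earlier step of a number 1.1 percentage points higher from compound 2 to compound 3 (within the scatter) and on the value of compound 1, 82.9%. Compound 4 is therefore expected to give about 83.5%, estimated to fall between 75% and 91%.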

Compound 4, percent growth inhibition at one concentration: 84.5%
For compound 4 the middle estimate is 1 percentage points below the measured one, and the stated range covers the measured number.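

In this assay fluoro in place of hydrogen on an aromatic carbon of the core of compound 1 gives a number 1.6 percentage points higher from compound 1 to compound 4 (within the scatter) on this core, and the step can be set beside the one on the core of compound 2. The change carries across these two cores with no difference in size that can be told apart: the same change on two cores in this assay, a number 1.1 percentage points higher (within the scatter) from compound 2 to compound 3 and a number 1.6 percentage points higher (within the scatter) from compound 1 to compound 4, 0.5 percentage points apart, within the scatter of two such steps. Within the data shown here, this shows only that the change leaves the reading within the scatter on both cores; it does not show that fluoro raises growth inhibition on either core, and two cores tested at one concentration make no rule for the series.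

The compounds shown leave open whether a group such as chloro, methoxy or an amine, placed on the same aromatic carbon, would move the reading beyond the scatter on either core. On these data alone, it also remains open whether the fluoro step would stay this small on a third core.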